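Swapping a dichlorophenyl for a chlorobenzyl on the amide

A few compounds are considered here, and "the series" means these few. Any claim that something is new, unique, unknown or untested is made for them only; others in the source may bear on it.

Compound 1 `O=C(CCSc1nnc(-c2ccncc2)s1)Nc1c(Cl)cccc1Cl` and compound 2 `O=C(CCSc1nnc(-c2ccncc2)s1)Nc1ccc(Cl)cc1Cl` share one core and differ only at the amide-type nitrogen. In an ADME assay on BHK-21 cells (Mesocricetus auratus) for cytotoxicity, with a stated time of 3 days (on this read-out higher numbers stand for lower toxicity in this test and lower numbers for higher toxicity in this test), compound 1 gives 10300 nM. Compound 2 reaches only > 50000 nM, which is a limit of the assay, not a number. The step of an at least 4.8-fold higher number from compound 1 to compound 2 (0.68 log units; beyond the scatter) is thus known only as a bound, as the limit of > 50000 nM in this assay, at which 1 of the 2 values shown sits, shows. Compound 3 `O=C(CCSc1nnc(-c2ccncc2)s1)NCc1ccccc1Cl` carries 2-chlorobenzyl in place of 2,4-dichlorophenyl on an amide-type nitrogen. For the measured compounds named here, no measured step covers a benzyl group, so the expected step of an at least 1.6-fold lower number from compound 2 to compound 3 (0.22 log units; that floor lies within the scatter) is modest at most, possibly none beyond the scatter. Compound 3 is expected to give 30000 nM, between 8000 nM and 100000 nM.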

Compound 3, half-maximal cytotoxic concentration: > 50000 nM
Compound 3 was reported as a limit (the forecaster's own chance of this, stated with the estimate: 45%); middle value at least 1.6-fold (0.22 log units) away from the limit.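

At the amide-type nitrogen, 2-chlorobenzyl in place of 2,6-dichlorophenyl gives an at least 4.8-fold higher number from compound 1 to compound 3 (0.68 log units; beyond the scatter) in this assay, so a benzyl group here also moves the read-out away from that of compound 1. Of the groups shown, only the 2,6-dichlorophenyl of compound 1 gives a measured number rather than a limit. The comparison of compound 2 with compound 3 cannot be read, because both values are limits and not numbers: the limit of > 50000 nM in this assay, at which 2 of the 3 values shown sit.

As far as these compounds go, whether the two truly differ stays open. So does the outcome for a plain benzyl without chlorine, or for a longer chain such as 2-phenylethyl, on this nitrogen.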